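Cytotoxicity on Vero cells: a dimethylamino for pyrrolidinyl swap

The source may report more compounds than this note shows. Statements on the series, on what has been measured and on what is new or still open speak of the compounds shown alone.

Measured compounds:
compound 1 `CN(C)c1cc2[nH]c(C3CCCCC3)nc2cc1NC(=O)c1cccs1` gives > 100 ug/mL in an ADME assay on Vero cells (Chlorocebus sabaeus) for cytotoxicity, read by resazurin assay, with a stated time of 3 days (on this read-out higher numbers stand for weaker inhibition and lower numbers for stronger inhibition), a limit of the assay.
compound 2 `CCCc1ccc(C(=O)Nc2cc3nc(C4CCCCC4)[nH]c3cc2N(C)C)cc1` gives > 100 ug/mL in this assay, a limit of the assay.
compound 3 `Cc1ccc(C(=O)Nc2cc3nc(C4CCCCC4)[nH]c3cc2N2CCCC2)cc1` gives > 100 ug/mL in this assay, a limit of the assay.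

All three measured values sit at one and the same limit: the limit of > 100 ug/mL in this assay, at which 3 of the 3 values shown sit. Compound 3 therefore stands at the limit, not at a number, alongside the other two. The step from compound 1 to compound 2 is a step that the two limits leave unreadable from compound 1 to compound 2, so it says nothing about size. Compound 4 `Cc1ccc(C(=O)Nc2cc3nc(C4CCCCC4)[nH]c3cc2N(C)C)cc1` differs from compound 3 by dimethylamino in place of pyrrolidin-1-yl on an aromatic carbon. Going by the values given here, no measured step bears directly on this change; the only guide is that compounds 1 and 2, both carrying dimethylamino, also sit at the limit. Compound 4 is therefore expected to give 150 ug/mL (range 60 ug/mL to 400 ug/mL), with the step from compound 3 to compound 4 estimated as a step that the limit leaves unreadable from compound 3 to compound 4, none beyond scatter, because of the limit of > 100 ug/mL in this assay, at which 3 of the 3 values shown sit.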

Compound 4, half-maximal inhibitory concentration: > 100 ug/mL
Compound 4: only a limit was reported; the forecaster's own chance of this, stated with the estimate: 85%; the middle value does not contradict the limit.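

Going by these compounds alone, compound 4, like compound 1, compound 2 and compound 3, reaches only a limit in this assay, so no step among them can be read: the limit of > 100 ug/mL in this assay, at which 4 of the 4 values shown sit. The compounds shown leave open whether any of these changes alters cytotoxicity at all.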